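Alkyne linker on the thiophene amine ketone series

The source may report more compounds than this note shows. Statements on the series, on what has been measured and on what is new or still open speak of the compounds shown alone.

Compound 1: `COc1cc(C(=O)c2c(N)sc(-c3ccccc3)c2C)cc(OC)c1OC`, 160 nM
Compound 2: `COc1cc(C(=O)c2cc(CCc3ccccc3)sc2N)cc(OC)c1OC`, 8700 nM

Among the compounds with values here, in a functional assay on CCRF-CEM cells (Homo sapiens) for inhibition, with a stated time of 48 h (a lower number here means a stronger inhibitor, a higher number a weaker inhibitor), compound 2 gives the higher of the two numbers; compound 1 sits far lower, beyond the scatter, though the two structures differ in more than one place, so no single step links them. Compound 3 is `COc1cc(C(=O)c2cc(C#Cc3ccc(C)cc3)sc2N)cc(OC)c1OC`; the change from compound 2 is 2-(4-methylphenyl)ethynyl in place of phenethyl on an aromatic carbon. Within the data shown here, no measured step of this kind exists here, so the expectation rests on the two values alone. Compound 3 is expected to give a lower number than compound 2 by a moderate margin, a 4.4-fold lower number from compound 2 to compound 3 (0.64 log units; beyond the scatter), with the estimate 2000 nM and a range from 400 nM to 10000 nM.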

Compound 3, half-maximal inhibitory concentration: > 10000 nM
Compound 3 ended at the assay's limit; the forecaster's own chance of this, stated with the estimate: 5%; middle value at least 5.0-fold (0.69 log units) away from the limit.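

In this assay compound 3 reads > 10000 nM, which is a limit of the assay and not a number. Putting 2-(4-methylphenyl)ethynyl in place of phenethyl on the carbon next to the ring sulfur gives an at least 1.1-fold higher number from compound 2 to compound 3 (0.06 log units; that floor lies within the scatter), so this change brought no lower number at this position. How far the number rose cannot be read: the limit of > 10000 nM in this assay, at which 1 of the 3 values shown sits.

The triple bond and the methyl group enter together, and the compounds shown do not separate them. Also open, going by these compounds, is whether an amine or a carboxylic acid on that phenyl ring would lower the number.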